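Shortening the amide substituent from cyclopropylmethyl to cyclopropyl

This account rests on a few compounds, and the source may have more. Where it says the series, first, only, none or still open, it means among the compounds named here.

Measured compounds:
compound 1, `Cc1cccc2c1CC/C2=C\C(=O)NC1CC1`: 7%
compound 2, `O=C(/C=C1\CCc2ccc(F)cc21)NCC1CC1`: 21%
compound 3, `NC(=O)/C=C1\CCc2c1ccc(F)c2F`: 82%

All three were tested in a functional assay on the whole organism with Rattus norvegicus as the target, at a dose of 20 mg/kg by the oral route; a lower number here means less inhibition, a higher number more inhibition at the dose given (going by the name of the read-out). Among the three numbers, compound 2 stands second highest: its nearest neighbour is compound 1, whose value lies lower by a margin beyond the scatter, while compound 3 lies far above it, also beyond the scatter. No pair of these compounds differs in one place only, so the three values describe three separate substances rather than a chain of single changes.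

Compound 4, `O=C(/C=C1\CCc2ccc(F)cc21)NC1CC1`, has not yet been measured. It shares its core with compound 2 and differs from it in one place: cyclopropyl in place of cyclopropylmethyl on an amide-type nitrogen. Among the measured compounds shown here, compound 1 carries a cyclopropyl amide on a different core and gives a low number in this assay, but no step connects that compound to compound 2, so it gives only a loose hint. The step from compound 2 to compound 4 is therefore expected to be small, of the order of the scatter or slightly downward, as a number 3 percentage points lower from compound 2 to compound 4 (within the scatter). In this assay compound 4 is estimated to give 18%, with a range from 4% to 40%.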

Compound 4, a percentage reported as inhibition, in the whole organism at one dose (the size of the read-out at that dose, not a potency): 7%
Compound 4: the middle estimate sits 11 percentage points above what was measured; low and high end bracket the measured number.
By their numbers in this assay, from the lowest: compounds 1 and 4 (each within the scatter of the next); then compound 2; then compound 3.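

In this assay, among the compounds shown here, the exchange of cyclopropylmethyl for cyclopropyl on the amide-type nitrogen gives the first step that can be read in this set: a number 14 percentage points lower from compound 2 to compound 4 (beyond the scatter). This shows that, on the shared core, the number responds to this position and that even this small shortening of the substituent moves it by more than the usual scatter, though the step is only modest and points downward, with compound 4 at 7% in this assay. No measurement shown here accounts for the direction or size of this step.

The compounds leave open how other groups on this nitrogen would read on the same core, such as a methyl, a longer chain like n-butyl, or a chain ending in an amine or a carboxylic acid, and how the same core would read with the unsubstituted amide that compound 3 carries on its own core. With a single step at one position, they also leave open whether the exchange of cyclopropylmethyl for cyclopropyl would run the same way on any other core.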